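Swapping the cyanophenyl of compound 3 for fluorophenyl

This account rests on a few compounds, and the source may have more. Where it says the series, first, only, none or still open, it means among the compounds named here.

Measured so far:
compound 1 `O=[N+]([O-])c1ccc(CN2CCC(n3cc(CC(OCc4cc(-c5ccccc5)no4)c4ccc(Br)cc4)nn3)CC2)cc1`; in a functional assay on MCF7 cells (Homo sapiens) for cytotoxicity, with a stated time of 48 h (a lower number here means a stronger inhibitor, a higher number a weaker inhibitor), compound 1 gives > 25000 nM, a limit of the assay.
compound 2 `O=[N+]([O-])c1ccc(CN2CCC(n3cc(CC(OCc4cc(-c5cccc(F)c5)no4)c4ccc(Br)cc4)nn3)CC2)cc1`; in this assay compound 2 gives 8000 nM.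
compound 3 `N#Cc1cccc(-c2cc(COC(Cc3cn(C4CCN(Cc5ccc([N+](=O)[O-])cc5)CC4)nn3)c3ccc(Br)cc3)on2)c1`; in this assay compound 3 gives 2000 nM.

Compound 3 gives the lowest of the two numbers; its nearest neighbour is compound 2, separated by the step of a 4.0-fold lower number from compound 2 to compound 3 (0.60 log units; beyond the scatter). Compound 4 `O=[N+]([O-])c1ccc(CN2CCC(n3cc(CC(OCc4cc(-c5ccccc5F)no4)c4ccc(Br)cc4)nn3)CC2)cc1` differs from compound 3 by 2-fluorophenyl in place of 3-cyanophenyl on an aromatic carbon. Of the measured steps, a 4.0-fold lower number from compound 2 to compound 3 (0.60 log units; beyond the scatter), which likewise trades cyano against fluoro, bears most directly on this change, though the fluoro of compound 4 enters as 2-fluorophenyl rather than as in compound 2. The steps of an at least 3.1-fold lower number from compound 1 to compound 2 (0.49 log units; beyond the scatter) and an at least 12-fold lower number from compound 1 to compound 3 (1.09 log units; beyond the scatter) show that the unsubstituted ring of compound 1 rests at the limit (the limit of > 25000 nM in this assay, at which 1 of the 3 values shown sits). Compound 4 is therefore expected to weaken, with an estimated step of a 4.0-fold higher number from compound 3 to compound 4 (0.60 log units; beyond the scatter). The expected value for compound 4 is 8000 nM, within 2500 nM to 25000 nM.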

Compound 4, half-maximal inhibitory concentration: 8000 nM
Compound 4: the middle estimate sits on the measured number at the digits printed, within the range that was stated.
By their numbers in this assay, from the lowest: compound 3; then compounds 2 and 4 (each within the scatter of the next). At a limit, above all of these: compound 1.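

In this assay, 2-fluorophenyl and 3-fluorophenyl on this aromatic carbon cannot be told apart, with no change at the digits printed from compound 2 to compound 4 (within the scatter). The gain over unsubstituted phenyl therefore appears with the fluoro in either placement, with an at least 3.1-fold lower number from compound 1 to compound 4 (0.49 log units; beyond the scatter), while 3-cyanophenyl keeps the lower number, with a 4.0-fold higher number from compound 3 to compound 4 (0.60 log units; beyond the scatter). Compound 1 stands only as a limit: the limit of > 25000 nM in this assay, at which 1 of the 4 values shown sits.

The compounds shown leave open whether the nitrile would keep the number of compound 3 as 2-cyanophenyl. They also leave open how an amine or a carboxylic acid on this phenyl ring would compare.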